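This account rests on a few compounds, and the source may have more. Where it says the series, first, only, none or still open, it means among the compounds named here.

In a functional assay on HCT-116 cells (Homo sapiens) for antiproliferative activity, read by MTT assay, with a stated time of 72 h (a lower number here means a stronger inhibitor, a higher number a weaker inhibitor), compound 1 `COc1ccc(N2CCN(C(=S)SCc3ccc4nc(N)nc(N)c4c3)CC2)cc1` gives 2270 nM and compound 2 `Nc1nc(N)c2cc(CSC(=S)N3CCN(c4ccc(F)cc4)CC3)ccc2n1` gives 3270 nM; these two values lie within the scatter of each other. Compound 3 `Nc1nc(N)c2cc(CSC(=S)N3CCN(c4ccc([N+](=O)[O-])cc4)CC3)ccc2n1` differs from compound 2 by nitro in place of fluoro on an aromatic carbon. Among the compounds with values here, the only measured step at that place, a 1.4-fold higher number from compound 1 to compound 2 (0.16 log units; within the scatter), put fluoro in place of methoxy and stayed within the scatter. On these data alone, no step beyond the scatter is therefore expected in this assay, although a single step is thin evidence and nitro itself is untested. The expected change is a 1.2-fold lower number from compound 2 to compound 3 (0.07 log units; within the scatter). Compound 3 is estimated at 2800 nM, with an expected range from 1000 nM to 8000 nM.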

Compound 3, half-maximal inhibitory concentration: 4680 nM
Estimate against measurement, compound 3: 1.7-fold (0.22 log units) below; the measured number falls inside the stated range.
By their numbers in this assay, from the lowest: compounds 1, 2 and 3 (each within the scatter of the next, the first and the last beyond it).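

In this assay the exchange of fluoro for nitro, on an aromatic carbon para to a large group, stays within the scatter (a 1.4-fold higher number from compound 2 to compound 3 (0.16 log units; within the scatter)). Nitro in place of methoxy at the same carbon is the only step here beyond the scatter, and only modestly so (a 2.1-fold higher number from compound 1 to compound 3 (0.31 log units; beyond the scatter)). No measured evidence is available to explain this step.

On these data alone, whether an amine or a carboxylic acid at this position would give a number within the scatter of these three stays open.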